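Trimethoxy, Methoxy, Furan: Choosing the Second Aryl Cap

A few compounds are considered here, and "the series" means these few. Any claim that something is new, unique, unknown or untested is made for them only; others in the source may bear on it.

The measured compounds:
Compound 1, `COc1ccccc1/C=C/C(=O)/C=C/c1ccc(OCc2cn(CCCOc3cc(=O)oc4ccccc34)nn2)c(OC)c1`, 53%.
Compound 2, `COc1cc(/C=C/C(=O)/C=C/c2cc(OC)c(OC)c(OC)c2)ccc1OCc1cn(CCCOc2cc(=O)oc3ccccc23)nn1`, 76%.
Compound 3, `COc1cc(/C=C/C(=O)/C=C/c2ccco2)ccc1OCc1cn(CCCOc2cc(=O)oc3ccccc23)nn1`, 51%.

All three were tested in a functional assay on HCT-116 cells (Homo sapiens) for inhibition, read by sulforhodamine B assay, with a stated time of 48 h, tested at 50 uM; a lower number here means less inhibition of growth, a higher number more inhibition of growth at the concentration tested. Compound 3 has the lowest of the three numbers; its nearest neighbour is compound 1, while compound 2 lies furthest from it. The step of a number 25 percentage points lower from compound 2 to compound 3 (beyond the scatter) is beyond the scatter, whereas a number 2 percentage points lower from compound 1 to compound 3 (within the scatter) is within it, so the furan-2-yl cap sits level with the 2-methoxyphenyl cap and well below the 3,4,5-trimethoxyphenyl cap.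

Compound 4, `COc1ccc(/C=C/C(=O)/C=C/c2ccc(OCc3cn(CCCOc4cc(=O)oc5ccccc45)nn3)c(OC)c2)cc1OC`, has not yet been measured. It differs from compound 3 in one place: 3,4-dimethoxyphenyl in place of furan-2-yl on a double-bonded chain carbon bound to a double-bonded chain carbon. The step that bears most directly on this change is a number 25 percentage points lower from compound 2 to compound 3 (beyond the scatter), the move from a methoxy-bearing phenyl to the furan; reversed, a methoxy-bearing phenyl entering in place of the furan should raise the number. Compound 1 cautions that not every methoxyphenyl does so, since a number 2 percentage points lower from compound 1 to compound 3 (within the scatter) was flat. With two methoxy groups rather than one or three, compound 4 is expected to land between these cases, an estimated a number 14 percentage points higher from compound 3 to compound 4 (beyond the scatter) upward. Compound 4 is therefore estimated at 65%, in the range 50% to 80%.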

Compound 4, percent growth inhibition at one concentration: 67%
The estimate for compound 4 lay 2 percentage points below the measured number; measured number inside the range.
By their numbers in this assay, from the lowest: compounds 3 and 1 (each within the scatter of the next); then compounds 4 and 2 (each within the scatter of the next).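

In this assay, a second methoxy-bearing cap now stands clear of the furan-2-yl cap, with a number 16 percentage points higher from compound 3 to compound 4 (beyond the scatter), and also clear of the 2-methoxyphenyl cap, with a number 14 percentage points higher from compound 1 to compound 4 (beyond the scatter), so a methoxyphenyl at this place does not by itself settle the result. The 3,4,5-trimethoxyphenyl cap also loses its standing as the only high cap, since hydrogen in place of methoxy on an aromatic carbon gives a number 9 percentage points lower from compound 2 to compound 4 (within the scatter). Nothing available here accounts for these differences.

The compounds shown leave open whether a phenyl cap carrying a hydroxyl or a dimethylamino group in place of the methoxy groups would stay level with compound 4. They also leave open how a pyridine ring would compare with the furan-2-yl cap at this place.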